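The compounds below may be only part of what the source reports. "The series", "measured", "known", "first", "only" and "open" are said of these compounds alone.

In a physicochemical assay for solubility, with a stated time of 24 h, tested at 30 mg/mL (on this read-out higher numbers stand for higher solubility and lower numbers for lower solubility), compound 1 `COc1ccc(Nc2c(NCCCCCC(=O)NO)c(=O)c2=O)cc1` gives 300000 nM and compound 2 `CC(CCCCC(=O)NO)Nc1c(Nc2ccccc2)c(=O)c1=O` gives 46000000 nM, while compound 3 `Cc1ccc(Nc2c(NC(C)CCCCC(=O)NO)c(=O)c2=O)cc1` gives 4900000 nM as the second highest number of the three. Compound 4 `COc1ccc(Nc2c(NC(C)CCCCC(=O)NO)c(=O)c2=O)cc1` remains unmeasured. It carries methoxy in place of methyl on an aromatic carbon, para to a large group, the change methoxy in place of methyl on an aromatic carbon that turns 4-methylphenyl into 4-methoxyphenyl. For the measured compounds named here, the one measured step in a single place, a 9.4-fold lower number from compound 2 to compound 3 (0.97 log units; beyond the scatter) for methyl in place of hydrogen on an aromatic carbon, is modest and does not test methoxy against methyl. Going by the values given here, compound 1 also bears 4-methoxyphenyl and gives 300000 nM as the lowest of the three, yet no measured step isolates that group. On this thin evidence, a step smaller than a 9.4-fold lower number from compound 2 to compound 3 (0.97 log units; beyond the scatter) is expected in this assay with a slight lean to lower numbers, possibly none beyond the scatter. The expected step is a 1.6-fold lower number from compound 3 to compound 4 (0.21 log units; within the scatter) in this estimate. For compound 4 the estimated value is 3000000 nM with an expected range from 800000 nM to 10000000 nM on this read-out.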

Compound 4, solubility: 11000000 nM
For compound 4 the middle estimate is 3.7-fold (0.56 log units) below the measured one, and the stated range ends below it.
By their numbers in this assay, from the lowest: compound 1; then compound 3; then compound 4; then compound 2.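

In this assay, methoxy in place of methyl on an aromatic carbon, para to a large group, gives a 2.2-fold higher number from compound 3 to compound 4 (0.35 log units; beyond the scatter), the first direct test of 4-methoxyphenyl against 4-methylphenyl, and it shows that this position separates the two groups beyond the scatter. With hydrogen as the reference, methoxy gives a 4.2-fold lower number from compound 2 to compound 4 (0.62 log units; beyond the scatter), so both groups now give lower numbers than hydrogen at this place, methyl with a 9.4-fold lower number from compound 2 to compound 3 (0.97 log units; beyond the scatter), while methyl in place of hydrogen on a saturated chain carbon bound to a nitrogen on an aromatic ring and a saturated chain carbon gives a 37-fold higher number from compound 1 to compound 4 (1.56 log units; beyond the scatter), the largest step shown. Nothing available here accounts for these steps.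

The compounds shown leave open how an amine or a carboxylic acid would compare with methoxy on this aromatic carbon. They also leave open whether the step at the saturated chain carbon holds with 4-methylphenyl or with a longer chain.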